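Chloro in place of bromo on two cores

A few compounds are considered here, and "the series" means these few. Any claim that something is new, unique, unknown or untested is made for them only; others in the source may bear on it.

Measured so far:
compound 1 `COc1ccc(C2=NN(C3=NC(=O)/C(=C4\C(=O)Nc5ccc(Br)cc54)S3)C(c3ccc(Cl)cc3)C2)cc1`: 180 nM
compound 2 `COc1ccc(C2=NN(C3=NC(=O)/C(=C4\C(=O)Nc5ccc(Cl)cc54)S3)C(c3ccc(Cl)cc3)C2)cc1`: 270 nM
compound 3 `CN(C)c1ccc(C2CC(c3ccccc3)=NN2C2=NC(=O)/C(=C3\C(=O)Nc4ccc(Br)cc43)S2)cc1`: 270 nM

Of the compounds shown here, three have been measured in a functional assay on cells (Cancer cell lines, Homo sapiens) for cytotoxicity, read by sulforhodamine B assay, with a stated time of 48 h; on this read-out higher numbers stand for weaker inhibition of growth and lower numbers for stronger inhibition of growth. Compound 1 and compound 2 share one core and differ by chloro in place of bromo on an aromatic carbon; the step is a 1.5-fold higher number from compound 1 to compound 2 (0.18 log units; within the scatter). Compound 3 carries a different core; the difference between the core of compound 1 and the core of compound 3 is not broken down here. In this assay compound 3 gives 270 nM, level with compound 2 at the digits shown, and the values of compound 3 and compound 1 lie within the scatter of each other.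

Compound 4 `CN(C)c1ccc(C2CC(c3ccccc3)=NN2C2=NC(=O)/C(=C3\C(=O)Nc4ccc(Cl)cc43)S2)cc1` has not yet been measured. It differs from compound 3 by chloro in place of bromo on an aromatic carbon, the same change as made from compound 1 to compound 2, now on the second core; the surroundings of the place are the same in both cases. Among the compounds with values here, the step of a 1.5-fold higher number from compound 3 to compound 4 (0.17 log units; within the scatter) is expected to be of about the same size as the earlier one, because the only comparable step a 1.5-fold higher number from compound 1 to compound 2 (0.18 log units; within the scatter) stayed within the scatter. Compound 4 is therefore estimated at 400 nM in this assay, with a range from 200 nM to 800 nM.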

Compound 4, concentration for 50% growth inhibition: 250 nM
Compound 4: middle estimate off by 1.6-fold (0.20 log units), on the high side, within the range that was stated.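

In this assay, chloro in place of bromo on the second core gives a 1.1-fold lower number from compound 3 to compound 4 (0.03 log units; within the scatter), and this step agrees with the one on the first core within the scatter: the same change on two cores in this assay, a 1.5-fold higher number (0.18 log units; within the scatter) from compound 1 to compound 2 and a 1.1-fold lower number (0.03 log units; within the scatter) from compound 3 to compound 4, 1.6-fold (0.21 log units) apart, within the scatter of two such steps. On these two cores, then, chloro and bromo at this aromatic carbon cannot be told apart on this read-out, and the change carries from the core of compound 1 to the core of compound 3 without a detectable difference. Two pairs in a single assay do not show that the same would hold on a further core, and they give no ground for preferring either halogen.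

The compounds shown leave open whether a group other than these two halogens at this place, such as fluoro, a nitrile or a carboxylic acid, would shift growth inhibition beyond the scatter. From the compounds shown here alone, the two cores differ in more than one place, and what each of those differences contributes also remains open.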